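The compounds below may be only part of what the source reports. "The series", "measured", "known", "first", "only" and "open" are said of these compounds alone.

In an assay on A7R5 cells for displacement of a labelled ligand from Endothelin-1 receptor (Rattus norvegicus) (on this read-out lower numbers stand for stronger inhibition and higher numbers for weaker inhibition), three compounds have been measured: compound 1 `COc1cccc(Sc2c(NS(=O)(=O)c3ccc(C(C)(C)C)cc3)noc2CCCC#N)c1` gives 1300 nM; compound 2 `COc1cccc(Sc2c(NS(=O)(=O)c3ccc(C(C)(C)C)cc3)noc2CCC/C=N/O)c1` gives 1500 nM; compound 3 `COc1cccc(Sc2c(NS(=O)(=O)c3ccc(C(C)(C)C)cc3)noc2C)c1` gives 530 nM.

Compound 3 stands lowest of the three, with a 2.5-fold lower number from compound 1 to compound 3 (0.39 log units; beyond the scatter) and a 2.8-fold lower number from compound 2 to compound 3 (0.45 log units; beyond the scatter). Compound 4 `CSc1c(NS(=O)(=O)c2ccc(C(C)(C)C)cc2)noc1C` differs from compound 3 by methyl in place of 3-methoxyphenyl on a sulfur. Among the compounds with values here, none of the measured steps touches the substituent on this sulfur; all three alter only the chain bound to the core, and a 1.2-fold higher number from compound 1 to compound 2 (0.06 log units; within the scatter) likewise says nothing about it. With no comparable measured change, the direction is open. Since the group that leaves carries a ring and the one that enters does not, a weaker result in this assay is estimated for compound 4, a 4.7-fold higher number from compound 3 to compound 4 (0.67 log units; beyond the scatter), with wide bounds. Compound 4 is therefore expected at 2500 nM, between 500 nM and 12000 nM.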

Compound 4, half-maximal inhibitory concentration: > 100000 nM
Compound 4: no number, only a limit; the forecaster's own chance of this, stated with the estimate: 15%; at least 40-fold (1.60 log units) between middle value and limit.
By their numbers in this assay, from the lowest: compound 3; then compounds 1 and 2 (each within the scatter of the next). At a limit, above all of these: compound 4.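

At the sulfur, methyl in place of 3-methoxyphenyl changes the result in this assay far more than any of the chain changes do, with an at least 180-fold higher number from compound 3 to compound 4 (2.27 log units; beyond the scatter), so this substituent matters much more to the read-out than the chain on the shared core. Compound 4 gives only a limit of the assay, the one such value among the compounds shown: the limit of > 100000 nM in this assay, at which 1 of the 4 values shown sits. As far as these compounds go, whether a plain phenyl or a benzyl on the sulfur would keep the value of compound 3 stays open. From the compounds shown here alone, the part played by the methoxy group stays open too.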